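Changing the aryl group on the chain carbon of compound 2

The source may hold more compounds than are shown below. What is called first, only, known or untested is meant among the compounds shown, and "the series" means these compounds.

In a functional assay on B16-F10 cells (Mus musculus) for cytotoxicity, read by MTT assay, with a stated time of 48 h (a lower number here means a stronger inhibitor, a higher number a weaker inhibitor), compound 2 `N#Cc1ccc(CN(C(=O)Nc2cc(C(F)(F)F)cc(C(F)(F)F)c2)n2cnnc2)cc1` gives 4510 nM, the lowest of the two numbers shown. Compound 1 `COc1ccc(CN(C(=O)Nc2ccc(F)c(Cl)c2)n2cnnc2)cc1OC` gives 20700 nM in this assay. Compound 3 `COc1ccc(CN(C(=O)Nc2ccc(C#N)cc2)n2cnnc2)cc1OC` reaches only the assay limit of > 50000 nM in this assay. Going by the values given here, the one measured step, an at least 2.4-fold higher number from compound 1 to compound 3 (0.38 log units; beyond the scatter), changes the group on an amide-type nitrogen, and its size is capped because the limit of > 50000 nM in this assay, at which 1 of the 3 values shown sits, applies. Among the compounds with values here, compound 4 `COc1cc(CN(C(=O)Nc2cc(C(F)(F)F)cc(C(F)(F)F)c2)n2cnnc2)cc(OC)c1OC` differs from compound 2 by 3,4,5-trimethoxyphenyl in place of 4-cyanophenyl on a saturated chain carbon bound to an amide-type nitrogen, a change on a different part of the shared core, on which no measured step bears. Without a guide, the number for compound 4 is expected to stay near that of compound 2. Compound 4 is therefore estimated at 8000 nM, between 2500 nM and 30000 nM. The expected step of a 1.8-fold higher number from compound 2 to compound 4 (0.25 log units; within the scatter) stays within the scatter.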

Compound 4, half-maximal inhibitory concentration: 5620 nM
Beside the measured number, compound 4's estimate is 1.4-fold (0.15 log units) above it; low and high end bracket the measured number.
By their numbers in this assay, from the lowest: compounds 2 and 4 (each within the scatter of the next); then compound 1. At a limit, above all of these: compound 3.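

In this assay, going by these compounds alone, replacing the aryl group on the saturated chain carbon gives a 1.2-fold higher number from compound 2 to compound 4 (0.10 log units; within the scatter), the first measured step at this position. On the shared core of compound 2, 3,4,5-trimethoxyphenyl and 4-cyanophenyl therefore cannot be told apart in this cell read-out, even though they differ in their atoms and hydrogen-bond acceptor counts. Nothing shown explains why these two groups read alike. As far as these compounds go, it remains open whether an aryl group carrying an amine, or a carboxylic acid at this position, would also read alike. From the compounds shown here alone, it also remains open whether this swap would behave the same way with the other groups on the amide-type nitrogen.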